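Aryl hydrazone swap on a dibutylamino cinnamic acid series

This account rests on a few compounds, and the source may have more. Where it says the series, first, only, none or still open, it means among the compounds named here.

Measured compounds in an assay on isolated protein for inhibition of Indoleamine 2,3-dioxygenase 1 (Homo sapiens), with a stated time of 30 min; a lower number here means a stronger inhibitor, a higher number a weaker inhibitor:
compound 1 `CCCCN(CCCC)c1ccc(/C(C)=C/C(=O)O)cc1NC(=O)N/N=C/c1ccc(Cl)cc1`, 14400 nM
compound 2 `CCCCN(CCCC)c1ccc(/C(C)=C/C(=O)O)cc1NC(=O)N/N=C/c1ccccc1C(F)(F)F`, 12400 nM
compound 3 `C/C(=C\C(=O)O)c1ccc(N(CC(C)C)CC(C)C)c(NC(=O)N/N=C/c2ccccc2F)c1`, 10100 nM

Compound 3 stands within the scatter of both its neighbours: compound 2 is nearest, and compound 1, the furthest, still lies within the scatter. Compound 4 `C/C(=C\C(=O)O)c1ccc(N(CC(C)C)CC(C)C)c(NC(=O)N/N=C/c2ccc(Cl)cc2)c1` is not yet measured. It differs from compound 3 by 4-chlorophenyl in place of 2-fluorophenyl on a carbon with a double bond to nitrogen. Going by the values given here, the only measured step that bears on this place is a 1.2-fold lower number from compound 1 to compound 2 (0.06 log units; within the scatter), an exchange of one aryl group for another on the same carbon, with no effect beyond the scatter. Compound 4 is therefore expected to show a 1.2-fold higher number from compound 3 to compound 4 (0.07 log units; within the scatter), no step beyond the scatter in either direction. The estimate for compound 4 in this assay is 12000 nM, with a range from 6000 nM to 25000 nM.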

Compound 4, half-maximal inhibitory concentration: 10200 nM
For compound 4 the middle estimate is 1.2-fold (0.07 log units) above the measured one, and the stated range covers the measured number.
By their numbers in this assay, from the lowest: compounds 3, 4, 2 and 1 (each within the scatter of the next).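

In this assay the exchange of 2-fluorophenyl for 4-chlorophenyl gives a 1.0-fold higher number from compound 3 to compound 4 (0.00 log units; within the scatter) and so stays within the scatter, showing that a second aryl exchange on this carbon, now with diisobutylamino on the core, has no effect beyond it. Going by these compounds alone, the first reading of the amine change, diisobutylamino in place of dibutylamino with 4-chlorophenyl kept, gives a 1.4-fold lower number from compound 1 to compound 4 (0.15 log units; within the scatter) and also stays within the scatter. No evidence is available to explain these small steps.

Going by these compounds, whether a pyridine ring or a cyclohexyl group on that carbon would move the number remains open. So does the effect of dimethylamino or a longer chain on the amine.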